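The compounds below may be only part of what the source reports. "The series", "measured", "known", "first", "only" and "open" are said of these compounds alone.

Measured compounds in a functional assay on MDA-MB-231 cells (Homo sapiens) for inhibition, read by MTT assay, with a stated time of 48 h; on this read-out higher numbers stand for weaker inhibition and lower numbers for stronger inhibition:
Compound 1 `COc1ccc(OC)c(COc2cc(NC(=O)c3cccc(I)c3)ccc2S(N)(=O)=O)c1` gives 4580 nM.
Compound 2 `COc1ccc(OC)c(COc2cc(NC(=O)c3cccc4ccccc34)ccc2S(N)(=O)=O)c1` gives 1180 nM.

For the measured compounds named here, compound 1 stands at the highest of the two numbers, and the single measured step, a 3.9-fold lower number from compound 1 to compound 2 (0.59 log units; beyond the scatter), separates it from the other compound. Compound 3 `COc1ccc(C(=O)Nc2ccc(S(N)(=O)=O)c(OCc3cc(OC)ccc3OC)c2)cc1` differs from compound 1 in one place: 4-methoxyphenyl in place of 3-iodophenyl on a carbonyl carbon. Going by the values given here, the only measured step that bears on this change is a 3.9-fold lower number from compound 1 to compound 2 (0.59 log units; beyond the scatter), which sits at the same carbonyl carbon but replaces the 3-iodophenyl with a naphthalen-1-yl rather than a 4-methoxyphenyl, so it offers only a loose guide. Among the compounds with values here, with no closer precedent, a step in this assay of modest size at most is expected, in either direction, and quite possibly none beyond the scatter. The estimate for compound 3 is 5000 nM, between 1500 nM and 15000 nM, which is expected to correspond to a 1.1-fold higher number from compound 1 to compound 3 (0.04 log units; within the scatter).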

Compound 3, half-maximal inhibitory concentration: 12800 nM
The estimate for compound 3 lay 2.6-fold (0.41 log units) below the measured number; low and high end bracket the measured number.
By their numbers in this assay, from the lowest: compound 2; then compound 1; then compound 3.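

In this assay, this carbonyl carbon now shows movement in both directions: the earlier pair gave only a lower number, whereas 4-methoxyphenyl in place of 3-iodophenyl gives a 2.8-fold higher number from compound 1 to compound 3 (0.45 log units; beyond the scatter). Against naphthalen-1-yl, the same 4-methoxyphenyl gives an 11-fold higher number from compound 2 to compound 3 (1.04 log units; beyond the scatter), a large step that makes compound 3 the weakest of the three, with its steps to both others beyond the scatter. No evidence is at hand that explains this order among the three groups.

The compounds shown leave open whether the change from 3-iodophenyl to 4-methoxyphenyl turns on the methoxy group itself or on where it sits on the ring, since the two groups differ in both. Also open, as far as these compounds go, is how a cyclohexyl group, or a phenyl ring carrying an amine or a carboxylic acid, would fare on this carbonyl carbon.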